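Swapping the amide chain of compound 2 for an ester-bearing chain

The source may hold more compounds than are shown below. What is called first, only, known or untested is meant among the compounds shown, and "the series" means these compounds.

Measured compounds:
compound 1 `Cc1ccc(C(=O)/C=C/C(=O)N2CCc3cc(Nc4ncc(C)c(-c5cnn(C(C)C)c5)n4)ccc3C2)cc1`: 1050 nM
compound 2 `Cc1cnc(Nc2ccc3c(c2)CCN(C(=O)/C=C/CN(C)C)C3)nc1-c1cnn(C(C)C)c1`: 6750 nM
compound 3 `Cc1ccc(C(=O)/C=C/C(=O)N2CCc3ccc(Nc4ncc(C)c(-c5cnn(C(C)C)c5)n4)cc3C2)cc1`: 2470 nM

In an ADME assay on Vero cells (Chlorocebus sabaeus) for cytotoxicity, read by MTT assay, with a stated time of 72 h (a lower number here means a stronger inhibitor, a higher number a weaker inhibitor), compound 2 gives the highest number of the three measured compounds, a weaker inhibitor than compound 3 and than compound 1, both gaps lying beyond the scatter. Compound 1 and compound 3 share the same chain and differ only in where it attaches to the shared core; their two values sit close to each other.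

Compound 4 `COC(=O)/C=C/CN1CCc2cc(Nc3ncc(C)c(-c4cnn(C(C)C)c4)n3)ccc2C1` carries a change on the ring amine nitrogen: 3-(methoxycarbonyl)prop-2-en-1-yl in place of (3-(dimethylamino)prop-1-en-1-yl)carbonyl on an amine nitrogen in a ring. The carbonyl that linked the chain to the ring in compound 2 is gone, and a methoxycarbonyl ends the new chain.

Going by the values given here, only one measured step exists, a 6.4-fold higher number from compound 1 to compound 2 (0.81 log units; beyond the scatter), and it alters the far end of the chain, not its link to the ring. Among the compounds with values here, no measured step tells what removing the carbonyl at the ring nitrogen does. Given that the three measured numbers all fall in a moderate range, compound 4 is expected to stay near compound 2, with a 1.1-fold lower number from compound 2 to compound 4 (0.05 log units; within the scatter) as the estimated step. The estimate for compound 4 in this assay is 6000 nM, within 2000 nM to 20000 nM.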

Compound 4, half-maximal inhibitory concentration: 2330 nM
Estimate against measurement, compound 4: 2.6-fold (0.41 log units) above, and the stated range covers the measured number.
By their numbers in this assay, from the lowest: compound 1; then compounds 4 and 3 (each within the scatter of the next); then compound 2.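

In this assay, the change on the amine nitrogen in a ring gives a 2.9-fold lower number from compound 2 to compound 4 (0.46 log units; beyond the scatter) and so shows that the number responds to a change at the ring nitrogen itself, whereas the earlier step altered only the far end of the chain. The step replaces (3-(dimethylamino)prop-1-en-1-yl)carbonyl with 3-(methoxycarbonyl)prop-2-en-1-yl, so the carbonyl on the ring nitrogen and the dimethylamino end leave together while a methoxycarbonyl enters. No measurement here explains the size of this step.

Which of these parts carries the step stays open: a chain that keeps the carbonyl on the ring nitrogen but ends in methoxycarbonyl, or one that lacks that carbonyl but keeps the dimethylamino end, would separate them. Also open, on these data alone, is how a carboxylic acid or a longer chain at this nitrogen would behave.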